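Swapping the urea aryl group in a pyrazole urea series

A few compounds are considered here, and "the series" means these few. Any claim that something is new, unique, unknown or untested is made for them only; others in the source may bear on it.

Compound 2 `COc1cc(Cl)cc(-c2nn(-c3cccc(NC(=O)Nc4ccc(Cl)c(Cl)c4)c3)cc2-c2ccncc2)c1` carries a 3,4-dichlorophenyl group on the urea, and in a functional assay on RXF 393 cells (Homo sapiens) for inhibition, read by sulforhodamine B assay, with a stated time of 48 h, tested at 0.1 uM (a higher number here means a weaker effect of the compound at the concentration tested, a lower number a stronger effect), compound 2 gives 101%. Its closest relative, compound 1 `COc1cc(Cl)cc(-c2nn(-c3cccc(NC(=O)Nc4ccc(Cl)c(C(F)(F)F)c4)c3)cc2-c2ccncc2)c1`, differs only by a trifluoromethyl in place of one chloro, and in this assay compound 1 gives 96%. The step of a number 5 percentage points higher from compound 1 to compound 2 (within the scatter) lies within the scatter, so compound 2 stands alongside compound 1 rather than apart from it, and both read as essentially inactive at the concentration tested.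

Compound 3 `COc1cc(Cl)cc(-c2nn(-c3cccc(NC(=O)Nc4cccc(C(F)(F)F)c4)c3)cc2-c2ccncc2)c1` is not yet measured. The change from compound 2 is 3-(trifluoromethyl)phenyl in place of 3,4-dichlorophenyl on an amide-type nitrogen. Among the compounds with values here, the only measured step that touches this part of the molecule, a number 5 percentage points higher from compound 1 to compound 2 (within the scatter), is a change of substituent on the same aryl ring and moved the number by no more than the scatter. Compound 3 is therefore expected to show a step of a number 3 percentage points lower from compound 2 to compound 3 (within the scatter), no larger than the scatter, in either direction. Compound 3 is estimated at 98%, with a range from 84% to 110%.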

Compound 3, a percentage reported as activity, at one concentration (the size of the read-out at that concentration, not a potency): 92%
For compound 3 the middle estimate is 6 percentage points above the measured one; the measured number falls inside the stated range.
By their numbers in this assay, from the lowest: compounds 3, 1 and 2 (each within the scatter of the next).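

Within the data shown here, compound 3 brings a change the earlier compounds did not show: hydrogen in place of chloro on an aromatic carbon, which gives (a number 4 percentage points lower from compound 1 to compound 3 (within the scatter)) in this assay and so removes a substituent from the urea aryl group instead of exchanging one. The full exchange of 3,4-dichlorophenyl for 3-(trifluoromethyl)phenyl on the amide-type nitrogen gives (a number 9 percentage points lower from compound 2 to compound 3 (within the scatter)), so neither this exchange nor the loss of the chloro separates compound 3 from its neighbours, and all three read as essentially inactive at the concentration tested. No supporting measurement is available to explain this flat result.

As far as these compounds go, all three aryl groups carry only chloro or trifluoromethyl, so it remains open whether an amine or a carboxylic acid on this ring, or an alkyl chain in place of the ring, would lower the number. A read-out at one concentration gives no potency, which also leaves open whether these compounds differ at higher concentrations, or whether changes elsewhere on the shared core would matter more than changes at this position.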